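Turning one stereocentre from R to S

The compounds below may be only part of what the source reports. "The series", "measured", "known", "first", "only" and "open" are said of these compounds alone.

In a functional assay on MCF7 cells (Homo sapiens) for cytotoxicity, read by sulforhodamine B assay, with a stated time of 48 h (on this read-out higher numbers stand for weaker inhibition of growth and lower numbers for stronger inhibition of growth), compound 1 `NCC1COCC(c2ccccc2)(c2ccccc2)O1` gives 74400 nM as its reading. Compound 2 `NC[C@@H]1COCC(c2ccccc2)(c2ccccc2)O1` gives 250000 nM as its reading, the higher of the two numbers and so the weaker inhibition of growth. Compound 3 `NC[C@H]1COCC(c2ccccc2)(c2ccccc2)O1` is still unmeasured. Its structural change is the two compounds have the same atoms and bonds and differ only in configuration as drawn: 1 of 1 stereo elements differ; a stereocentre at a saturated ring carbon is drawn R in compound 2 and S in compound 3 and nothing more, with a stereocentre at a saturated ring carbon drawn R in compound 2 and S in compound 3.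

Going by the values given here, one measured step bears on this: a 3.4-fold higher number from compound 1 to compound 2 (0.53 log units; beyond the scatter) in this assay and beyond the scatter. All that is known about that step is the fact that one of compounds 1 and 2 is drawn with a defined configuration and the other without, at the place where they differ and no more. If compound 1 holds both forms, then a 3.4-fold higher number from compound 1 to compound 2 (0.53 log units; beyond the scatter) suggests that the S form carries most of its growth inhibition, so a clear step toward a lower number is expected.

The expected step is a 5.6-fold lower number from compound 2 to compound 3 (0.74 log units; beyond the scatter) and it points toward stronger inhibition of growth. For compound 3 the estimated value is 45000 nM with an expected range from 20000 nM to 110000 nM in this read-out.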

Compound 3, concentration for 50% growth inhibition: 99000 nM
Compound 3: middle estimate off by 2.2-fold (0.34 log units), on the low side, within the range that was stated.
By their numbers in this assay, from the lowest: compounds 1 and 3 (each within the scatter of the next); then compound 2.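

With both drawn configurations in hand, the position can now be read directly in this assay: a 2.5-fold lower number from compound 2 to compound 3 (0.40 log units; beyond the scatter), so the configuration at this saturated ring carbon changes the reading by more than the scatter, and the cause can lie only in the one difference there is: the fact that compounds 2 and 3 differ only in the configuration as drawn. The S form also proves indistinguishable from the compound drawn without a configuration, with a 1.3-fold higher number from compound 1 to compound 3 (0.12 log units; within the scatter), and so compound 2 alone stands apart among the three. What that comparison rests on is a matter of drawing only, and it does not establish what compound 1 actually contains: the fact that one of compounds 1 and 3 is drawn with a defined configuration and the other without, at the place where they differ.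

Going by these compounds, whether compound 1 holds both forms, and in what proportion, stays open, so the gap between its reading and that of each defined form cannot be apportioned between them. Also open is whether the difference between the R and S forms persists with a carboxylic acid in place of the amine, or with the amine carried on a longer chain, since every compound shown keeps the same amine and the same shared core.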